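The compounds below may be only part of what the source reports. "The series", "measured", "known", "first", "only" and "open" are said of these compounds alone.

Compound 1 `COc1cc2nc(N3CCC(C(=O)NCCO)CC3)nc(N)c2cc1OC` carries a shared core with a six-membered saturated ring bearing a (2-hydroxyethyl)carbamoyl group. In an assay on isolated protein for displacement of a labelled ligand from Adrenergic receptor alpha-1 (Rattus norvegicus) (a higher number here means a weaker inhibitor, a lower number a stronger inhibitor), compound 1 gives 1.73 nM, the highest number of the three measured compounds. Compound 2 `COc1cc2nc(N3CCC(C(=O)N(C)Cc4ccccc4)CC3)nc(N)c2cc1OC` gives 0.2 nM and compound 3 `COc1cc2nc(N3CCC(C(=O)NCCOc4ccccc4)CC3)nc(N)c2cc1OC` gives 0.42 nM. The two measured steps from compound 1 both lower the number: an 8.7-fold lower number from compound 1 to compound 2 (0.94 log units; beyond the scatter) and a 4.1-fold lower number from compound 1 to compound 3 (0.61 log units; beyond the scatter). Compound 4 `CCCNC(=O)CC1CCN(c2nc(N)c3cc(OC)c(OC)cc3n2)CC1` differs from compound 1 as follows: (propylcarbamoyl)methyl in place of (2-hydroxyethyl)carbamoyl on a saturated ring carbon. Neither measured step covers this exact change, yet both alter the same region with a lower number, so a modest decrease is expected, a 1.7-fold lower number from compound 1 to compound 4 (0.24 log units; within the scatter). Compound 4 is therefore estimated at 1 nM, within 0.35 nM to 3 nM.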

Compound 4, inhibition constant: 0.65 nM
For compound 4 the middle estimate is 1.5-fold (0.19 log units) above the measured one; the range from low to high includes it.
By their numbers in this assay, from the lowest: compound 2; then compounds 3 and 4 (each within the scatter of the next); then compound 1.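

The swap gives a 2.7-fold lower number from compound 1 to compound 4 (0.43 log units; beyond the scatter). So on this saturated ring carbon a lower number does not require the phenyl ring carried by compounds 2 and 3. The entering group has no ring and no hydroxyl, and it holds its carbonyl one methylene further out, so several features change at once. No measurement here explains the step. On these data alone, whether propylcarbamoyl on that same ring carbon, or (2-hydroxyethyl)carbamoylmethyl, would give the same drop stays open. So does the effect of a carboxylic acid at the chain end.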